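Swapping a Methyl for a Hydroxy on the Amide Chain

The compounds below may be only part of what the source reports. "The series", "measured", "known", "first", "only" and "open" are said of these compounds alone.

Of the compounds shown here, two have been measured in an assay on HepG2 cells for displacement of a labelled ligand from Alpha-2C adrenergic receptor (Homo sapiens), tested at 0.1 uM; a lower number here means less inhibition, a higher number more inhibition at the concentration tested (going by the name of the read-out). Compound 1 `COc1cc2c(cc1OC)CN(Cc1ccc(OC)c3oc(-c4cccnc4)cc13)CC2` gives 62%. Among the compounds with values here, compound 2 `CCCNC(=O)c1cc2c(CN3CCc4cc(OC)c(OC)cc4C3)ccc(OC)c2o1` gives 20%, the lower of the two numbers; the only known step, a number 42 percentage points lower from compound 1 to compound 2 (beyond the scatter), was large and beyond the scatter. Compound 3 `COc1cc2c(cc1OC)CN(Cc1ccc(OC)c3oc(C(=O)NCCO)cc13)CC2` differs from compound 2 by hydroxy in place of methyl on a saturated chain carbon, two bonds along the chain from an amide-type nitrogen. Within the data shown here, no measured step touches this part of the molecule: the one step on record changes the group on the aromatic carbon, not the chain beside the amide, so it says nothing about the size or direction of the present change. With nothing to point either way, the expectation for this assay is a step of no change at the digits printed from compound 2 to compound 3 (within the scatter), within the scatter. Compound 3 is therefore estimated at 20%, with a range from 5% to 40%.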

Compound 3, a percentage reported as inhibition, at one concentration (the size of the read-out at that concentration, not a potency): 6%
The estimate for compound 3 lay 14 percentage points above the measured number, within the range that was stated.
By their numbers in this assay, from the lowest: compound 3; then compound 2; then compound 1.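

The amide chain is not a silent part of the molecule in this assay: hydroxy in place of methyl, a swap of one heavy atom that adds one hydrogen-bond donor and one hydrogen-bond acceptor, gives a modest step, a number 14 percentage points lower from compound 2 to compound 3 (beyond the scatter), so even this small change registers. On the aromatic carbon, the (2-hydroxyethyl)carbamoyl group in place of pyridin-3-yl gives a large step, a number 56 percentage points lower from compound 1 to compound 3 (beyond the scatter), which leaves pyridin-3-yl with the highest number of the three groups shown there. Nothing available explains why the number falls with either change.

On these data alone, whether the fall is particular to hydroxy remains open. An amine or a carboxylic acid in the same place, or a longer chain carrying the hydroxy, would show how far the trend extends.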